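Replacing the 2,5-dihydroxyphenyl group: notes on a small series

The source may hold more compounds than are shown below. What is called first, only, known or untested is meant among the compounds shown, and "the series" means these compounds.

Measured in a functional assay on cells (Cancer cell lines, Homo sapiens) for cytotoxicity, read by sulforhodamine B assay, with a stated time of 48 h; a higher number here means a weaker inhibitor of growth, a lower number a stronger inhibitor of growth:
Compound 1, `NS(=O)(=O)c1ccc(-n2nc(-c3ccc(Cl)cc3)cc2-c2cc(O)ccc2O)cc1`: compound 1 gives 16700 nM
Compound 2, `CC(=O)NS(=O)(=O)c1ccc(-n2nc(-c3ccccc3)cc2-c2cc(O)ccc2O)cc1`: compound 2 gives 91300 nM
Compound 3, `NS(=O)(=O)c1ccc(-n2nc(-c3ccc(Cl)cc3)cc2C2=CC(=O)C=CC2=O)cc1`: compound 3 gives 21900 nM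

Going by the values given here, the one measured change of a single group is a group of 8 heavy atoms (6 carbon, 2 oxygen; one six-membered non-aromatic ring of carbon only) in place of a group of 8 heavy atoms (6 carbon, 2 oxygen; one six-membered aromatic ring of carbon only), on an aromatic carbon. It gave a 1.3-fold higher number from compound 1 to compound 3 (0.12 log units; within the scatter), so within this pair the swap hardly moved the read-out. Compound 2 stands at the highest number of the three; the difference between the core of compound 2 and that of compound 1 is not broken down here.

Compound 4, `CC(=O)NS(=O)(=O)c1ccc(-n2nc(-c3ccccc3)cc2C2=CC(=O)C=CC2=O)cc1`, differs from compound 2 by a group of 8 heavy atoms (6 carbon, 2 oxygen; one six-membered non-aromatic ring of carbon only) in place of a group of 8 heavy atoms (6 carbon, 2 oxygen; one six-membered aromatic ring of carbon only), on an aromatic carbon. Among the compounds with values here, this is the same kind of change as the one from compound 1 to compound 3, not the same: in compound 2 the neighbouring ring atom bears a large group and the ring atom two bonds away bears a phenyl group, whereas in compound 1 those positions carry a 4-sulfamoylphenyl group and a 4-chlorophenyl group. The expected step is a 1.3-fold higher number from compound 2 to compound 4 (0.10 log units; within the scatter), resting on the step from compound 1 to compound 3 being a 1.3-fold higher number from compound 1 to compound 3 (0.12 log units; within the scatter). Compound 4 is therefore estimated at 115000 nM in this assay, expected to fall between 45000 nM and 300000 nM.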

Compound 4, concentration for 50% growth inhibition: 78500 nM
Compound 4: middle estimate off by 1.5-fold (0.17 log units), on the high side; measured number inside the range.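

On the core of compound 2, the change again left the read-out in this assay close to where it stood, with a 1.2-fold lower number from compound 2 to compound 4 (0.07 log units; within the scatter). Set beside the earlier pair, the change behaves alike on both cores: the same change on two cores in this assay, a 1.3-fold higher number (0.12 log units; within the scatter) from compound 1 to compound 3 and a 1.2-fold lower number (0.07 log units; within the scatter) from compound 2 to compound 4, 1.5-fold (0.18 log units) apart, within the scatter of two such steps. This supports carrying the change between these two cores as one of little size, but two pairs show nothing about other cores and do not explain why the read-out stays flat.

Open, from the compounds shown here alone, is how a plain phenyl group, or a phenyl group with a single hydroxyl, would compare with the 2,5-dihydroxyphenyl group on either core. Also open, going by these compounds, is how much of the gap between compound 1 and compound 2 comes from the chlorine and how much from the acetyl group.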